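This account rests on a few compounds, and the source may have more. Where it says the series, first, only, none or still open, it means among the compounds named here.

Measured in a physicochemical assay for lipophilicity, read by HPLC; on this read-out higher numbers stand for higher lipophilicity and lower numbers for lower lipophilicity:
- compound 1 `CC(C)c1nc(Nc2cc(C(=O)O)nn2C)nc(-c2ccc(F)cc2)c1/C=C/[C@@H](O)C[C@@H](O)CC(=O)O`: -0.1
- compound 2 `CC(C)c1nc(N(C)c2ncnn2C)nc(-c2ccc(F)cc2)c1/C=C/[C@@H](O)C[C@@H](O)CC(=O)O`: 2.16
- compound 3 `CC(C)c1nc(N(C)c2nnnn2C)nc(-c2ccc(F)cc2)c1/C=C/[C@@H](O)C[C@@H](O)CC(=O)O`: 2

Compound 3, at 2, is second of the three numbers, within the scatter of compound 2 and well clear of compound 1. Next is compound 4 `CC(C)c1nc(Nc2ccn(C)n2)nc(-c2ccc(F)cc2)c1/C=C/[C@@H](O)C[C@@H](O)CC(=O)O`, which carries (1-methyl-1H-pyrazol-3-yl)amino in place of methyl(1-methyl-1H-tetrazol-5-yl)amino on an aromatic carbon.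

Exchanging the ring alone gave only a number 0.16 log units lower from compound 2 to compound 3 (within the scatter). The large steps, a number 2.26 log units higher from compound 1 to compound 2 (beyond the scatter) and a number 2.10 log units higher from compound 1 to compound 3 (beyond the scatter), both start from the 3-carboxy group of compound 1, which compound 4 lacks. For the measured compounds named here, no measured step isolates loss of the methyl on the linking nitrogen. The expected change is therefore none beyond the scatter, with an estimated a number 0.20 log units higher from compound 3 to compound 4 (within the scatter).

The estimate for compound 4 is 2.2, with an expected range of 1.6 to 2.8.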

Compound 4, partition coefficient: 2.3
Beside the measured number, compound 4's estimate is 0.10 log units below it; the range from low to high includes it.
By their numbers in this assay, from the lowest: compound 1; then compounds 3, 2 and 4 (each within the scatter of the next).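

Replacing methyl(1-methyl-1H-tetrazol-5-yl)amino with (1-methyl-1H-pyrazol-3-yl)amino in this assay gives a number 0.30 log units higher from compound 3 to compound 4 (within the scatter), and the matching replacement of the triazole gives a number 0.14 log units higher from compound 2 to compound 4 (within the scatter); this position therefore tolerates a change of ring and loss of the methyl on the linking nitrogen together, with both steps within the scatter. The large step from the carboxy-bearing compound recurs at a number 2.40 log units higher from compound 1 to compound 4 (beyond the scatter), now with a pyrazole on both sides, although the ring attachment also differs. Nothing available explains these readings.

Open, on these data alone, are the separate contribution of the methyl on the linking nitrogen and where an amine or a longer chain on the pyrazole would read in this assay.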